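The compounds below may be only part of what the source reports. "The series", "measured", "known", "first", "only" and "open" are said of these compounds alone.

Compound 1 `Cc1ccc(-c2nc3ccccc3s2)cc1NC(=O)c1cc([N+](=O)[O-])c(N(C)C)cc1Cl`: > 25000 nM
Compound 2 `O=C(Nc1cccc(-c2nc3ccccc3s2)c1)c1cc([N+](=O)[O-])c(O)cc1Cl`: > 25000 nM
Compound 3 `Cc1cc(NC(=O)c2cc([N+](=O)[O-])ccc2Cl)cc(-c2nc3ccccc3s2)c1O`: > 25000 nM

All three entries come from an ADME assay on HepG2 cells (Homo sapiens) for cytotoxicity, with a stated time of 72 h (a lower number here means that less compound is needed, a higher number that more compound is needed for the effect), and each is a limit of the assay, not a number. Compound 1 therefore has no exact place in a ranking and shares its position with the other two: the limit of > 25000 nM in this assay, at which 3 of the 3 values shown sit.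

The compound still to be measured is compound 4 `Cc1ccc(-c2nc3ccccc3s2)cc1NC(=O)c1cc([N+](=O)[O-])ccc1Cl`. It differs from compound 1 by hydrogen in place of dimethylamino on an aromatic carbon. Among the measured compounds shown here, no step between measured compounds is available, so the data do not show directly what such a change does.

Compound 1 reads > 25000 nM, and this limit is the only anchor for the expectation that compound 4 will also show little effect in this assay. The expected a number no higher from compound 1 to compound 4 (the limit leaves the size open) is none beyond the scatter, in either direction. Another report of only a limit is the likeliest outcome. For compound 4 the estimated value is 25000 nM, with an expected range of 12000 nM to 50000 nM.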

Compound 4, half-maximal effective concentration: > 14000 nM
Compound 4 ended at the assay's limit; the forecaster's own chance of this, stated with the estimate: 80%; the middle value lies beyond the limit too.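

In this assay, compound 1 and compound 4 both end at limits of the assay, so the step between them cannot be read. The compounds shown leave open at what concentration any of them reaches the half-maximal effect, and whether replacing dimethylamino with hydrogen shifts it.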